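Acetyl on the Ring Nitrogen of Compound 1

The source may hold more compounds than are shown below. What is called first, only, known or untested is meant among the compounds shown, and "the series" means these compounds.

Measured so far:
compound 1 `COc1ccc(-c2c[nH]c(=O)n2-c2cc(OC)c(OC)c(OC)c2)cc1N` – > 50000 nM
compound 2 `COc1cc(NC(=O)n2cc(-c3ccc(O)cc3)n(-c3cc(OC)c(OC)c(OC)c3)c2=O)cc(OC)c1OC` – > 50000 nM
compound 3 `COc1ccc(-c2cn(C(=O)Nc3cc(OC)c(OC)c(OC)c3)c(=O)n2-c2cc(OC)c(OC)c(OC)c2)cc1OC` – > 50000 nM

Of the compounds shown here, three on the shared core have been tested in a functional assay on Bel-7402 cells (Homo sapiens) for cytotoxicity, read by MTT assay, with a stated time of 48 h; on this read-out lower numbers stand for stronger inhibition and higher numbers for weaker inhibition. Compound 1 gives > 50000 nM, which is a limit of the assay and not a number. Compound 2 gives > 50000 nM, again a limit. Compound 3 gives > 50000 nM, also a limit. Going by the values given here, the one pair that differs in a single place, from compound 2 to compound 3, shows a step that the two limits leave unreadable from compound 2 to compound 3, so its size cannot be read. All values shown sit at the limit of > 50000 nM in this assay, at which 3 of the 3 values shown sit. Compound 1 therefore stands at the limit, with no number that could rank it against the others.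

Compound 4 `COc1ccc(-c2cn(C(C)=O)c(=O)n2-c2cc(OC)c(OC)c(OC)c2)cc1N` differs from compound 1 by acetyl in place of hydrogen on an aromatic nitrogen. Among the compounds with values here, no measured pair varies the group on that ring nitrogen, so no measured step bears on this change. The expectation rests on compound 1 alone, which sits at > 50000 nM in this assay. Compound 4 is estimated at 50000 nM, with a range from 15000 nM to 150000 nM. This estimate means an expected step of a number no higher from compound 1 to compound 4 (the limit leaves the size open), with a further limit being the likeliest outcome.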

Compound 4, half-maximal inhibitory concentration: 600 nM
Compound 4: the middle estimate sits 83-fold (1.92 log units) above what was measured; the measured number lies below the stated range.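

In this assay, the ring nitrogen of the core of compound 1 proves highly responsive to substitution: acetyl in place of hydrogen there gives an at least 83-fold lower number from compound 1 to compound 4 (1.92 log units; beyond the scatter). The > 50000 nM of compound 1 is a limit and not a number, so the step is stated only as a bound. Compound 4 is the only compound shown with a measured number, while the step from compound 2 to compound 3 cannot be read and most values remain limits: the limit of > 50000 nM in this assay, at which 3 of the 4 values shown sit.

The compounds shown leave open whether this gain is specific to acetyl or would also appear with formyl, a longer propionyl chain or a simple methyl on that ring nitrogen. They also leave open whether acetyl would have the same effect if an amine or a hydroxyl replaced the 3-amino-4-methoxyphenyl group.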